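Fluoro in Place of Hydroxy on an Aryl Ester

This account rests on a few compounds, and the source may have more. Where it says the series, first, only, none or still open, it means among the compounds named here.

Three compounds sharing one core were tested in an ADME assay on cells (T-cell, Mus musculus, strain BALB/c) for cytotoxicity, read by MTT assay, with a stated time of 48 h; a higher number here means that more compound is tolerated, a lower number that less compound is tolerated. Compound 1 `C=C(CCc1cc(O)c2c(=O)cc(-c3ccccc3)oc2c1)Cc1c(Br)cccc1C(=O)CC` gives 379000 nM. Compound 2 `COC(=O)c1cc(O)ccc1OC(=O)COc1cc(O)c2c(=O)cc(-c3ccccc3)oc2c1` gives 263000 nM, the lowest of the three numbers, though compound 3 `COC(=O)c1c(C)cccc1OC(=O)COc1cc(O)c2c(=O)cc(-c3ccccc3)oc2c1`, at 298000 nM, and compound 1 both lie within the scatter of it. For the measured compounds named here, the single one-point step, a 1.1-fold higher number from compound 2 to compound 3 (0.05 log units; within the scatter), replaces one group with another on an oxygen next to a carbonyl group and moves nothing beyond the scatter. Compound 4 `COC(=O)c1cc(F)ccc1OC(=O)COc1cc(O)c2c(=O)cc(-c3ccccc3)oc2c1` differs from compound 2 by fluoro in place of hydroxy on an aromatic carbon. Going by the values given here, no measured step touches this position, and the only step available is flat, so compound 4 is expected to show a 1.1-fold higher number from compound 2 to compound 4 (0.04 log units; within the scatter), nothing beyond the scatter. The estimate for compound 4 is 290000 nM, between 150000 nM and 600000 nM.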

Compound 4, half-maximal cytotoxic concentration: 389000 nM
Beside the measured number, compound 4's estimate is 1.3-fold (0.13 log units) below it; low and high end bracket the measured number.
By their numbers in this assay, from the lowest: compounds 2, 3, 1 and 4 (each within the scatter of the next).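

In this assay, for the compounds shown here, fluoro in place of hydroxy on this aromatic carbon gives a 1.5-fold higher number from compound 2 to compound 4 (0.17 log units; within the scatter), the first measured step at this position, and it stays within the scatter. The change of the whole group on the oxygen next to a carbonyl group gives a 1.3-fold higher number from compound 3 to compound 4 (0.12 log units; within the scatter), also within the scatter. Losing the hydrogen-bond donor and acceptor counted for hydroxy thus goes with no step beyond the scatter here. No evidence is available that explains these numbers. From the compounds shown here alone, whether an amine or a carboxylic acid at this position would move the number beyond the scatter stays open.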